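Amino in place of ethyl on a saturated chain

A few compounds are considered here, and "the series" means these few. Any claim that something is new, unique, unknown or untested is made for them only; others in the source may bear on it.

Compound 1, `Cc1cn([C@H]2C[C@H](SSC(Cl)(Cl)Cl)[C@@H](CO)O2)c(=O)[nH]c1=O`, gives < 1.5 h in a physicochemical assay for metabolic stability, in the presence of a further agent that is not named here (on this read-out lower numbers stand for a shorter-lived compound and higher numbers for a longer-lived compound), which is a limit of the assay and not a number. Compound 2, `CCCCSS[C@H]1C[C@H](n2cc(C)c(=O)[nH]c2=O)O[C@@H]1CO`, gives < 8 h in this assay, again a limit rather than a number. Compound 3, `CCCCCCCCSS[C@H]1C[C@H](n2cc(C)c(=O)[nH]c2=O)O[C@@H]1CO`, gives < 8 h in this assay, once more a limit.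

Compound 2 therefore stands only at a limit, and no number exists among the three measured compounds, as the limit of < 1.5 h in this assay, at which 1 of the 3 values shown sits, and the limit of < 8 h in this assay, at which 2 of the 3 values shown sit, show. Compound 4, `Cc1cn([C@H]2C[C@H](SSCCN)[C@@H](CO)O2)c(=O)[nH]c1=O`, differs from compound 2 by amino in place of ethyl on a saturated chain carbon, two bonds along the chain from a sulfur. The nearest measured change is the lengthening of the same chain, a step that the two limits leave unreadable from compound 2 to compound 3, and the other two steps, a step that the two limits leave unreadable from compound 1 to compound 2 and a step that the two limits leave unreadable from compound 1 to compound 3, are equally unreadable. No direction or size can be taken from them, so the step in this assay from compound 2 to compound 4 is expected to be a step that the limit leaves unreadable from compound 2 to compound 4, likely hidden again by a limit. Compound 4 is estimated at 3 h, within 0.5 h to 8 h.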

Compound 4, half-life: < 8 h
Compound 4: a limit, no number (the forecaster's own chance of this, stated with the estimate: 70%); the middle value is on the limit's open side.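

Compound 4 also stands only at a limit in this assay, so its steps from compound 1, compound 2 and compound 3 cannot be read. The compounds shown leave open the actual half-life of each compound, and whether amino in place of ethyl changes it at all.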